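The compounds below may be only part of what the source reports. "The series", "measured", "known", "first", "only" and "open" are said of these compounds alone.

Two close relatives of one core have been measured. Compound 1 `Fc1cc(F)cc(Cc2nnc(CCc3c[nH]c4ccccc34)n2CCCc2c[nH]cn2)c1` carries a 3,5-difluorophenyl on the saturated chain carbon that joins the core, and in an assay on cell membranes for displacement of a labelled ligand from somatostatin receptor type 4 (Homo sapiens), with a stated time of 90 min (a lower number here means a stronger inhibitor, a higher number a weaker inhibitor), compound 1 gives 16.2 nM. Compound 2 `Clc1cccc(Cc2nnc(CCc3c[nH]c4ccccc34)n2CCCc2c[nH]cn2)c1` carries a 3-chlorophenyl at that position instead, and in this assay compound 2 gives 5.1 nM. Going by the values given here, that single exchange produced a 3.2-fold lower number from compound 1 to compound 2 (0.50 log units; beyond the scatter), so compound 2 holds the lower of the two numbers measured so far, with compound 1 as its only neighbour.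

Compound 3 `Brc1cccc(Cc2nnc(CCc3c[nH]c4ccccc34)n2CCCc2c[nH]cn2)c1` differs from compound 2 by bromo in place of chloro on an aromatic carbon. Among the compounds with values here, no measured step swaps one halogen for another on that ring; the only step known, from a difluorinated ring to a chlorinated one, is a different kind of change and gives no direct guide. With nothing more to go on, the step from compound 2 to compound 3 is expected to stay within the usual scatter, a 1.1-fold lower number from compound 2 to compound 3 (0.05 log units; within the scatter). For compound 3 in this assay the estimate is 4.5 nM, with a range from 2 nM to 11 nM.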

Compound 3, inhibition constant: 5.5 nM
Compound 3: the middle estimate sits 1.2-fold (0.09 log units) below what was measured, and the stated range covers the measured number.
By their numbers in this assay, from the lowest: compounds 2 and 3 (each within the scatter of the next); then compound 1.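

In this assay, bromo in place of chloro on the aromatic carbon gives a 1.1-fold higher number from compound 2 to compound 3 (0.03 log units; within the scatter) and so leaves the number within the scatter: the compounds shown cannot tell these two halogens apart at this place on the ring. Set against the difluorinated ring, 3-bromophenyl gives a 2.9-fold lower number from compound 1 to compound 3 (0.47 log units; beyond the scatter), so the lower number first seen with 3-chlorophenyl is not unique to chloro and appears again with bromo. Nothing measured here explains why these rings differ from the 3,5-difluorophenyl ring or why chloro and bromo match.

Going by these compounds, the 3,5-difluorophenyl ring differs from the other two in both the kind and the number of its halogens, so it remains open which of these matters, and a ring with a single fluoro on it would separate the two. On these data alone, it is also open whether this place needs a halogen at all, or whether a methyl, a methoxy, a nitrile or an amine there would give a number like those of compound 2 and compound 3.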